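The source may hold more compounds than are shown below. What is called first, only, known or untested is meant among the compounds shown, and "the series" means these compounds.

Measured so far in an ADME assay on microsomes (Mus musculus) for pharmacokinetics; a lower number here means slower removal, a higher number faster removal of the compound:
- compound 1 `CN1CCN(c2ccc(Nc3ncc4c(=O)c(-c5c(Cl)cccc5Cl)cn(C5CC5)c4n3)cc2)CC1`: 582 mL/min/kg
- compound 2 `CN1CCN(c2ccc(Nc3ncc4c(=O)c(-c5c(Cl)cccc5Cl)cn(C5COC5)c4n3)cc2)CC1`: 582 mL/min/kg
- compound 3 `CN(C)CCn1cc(-c2c(Cl)cccc2Cl)c(=O)c2cnc(Nc3ccc(N4CCN(C)CC4)cc3)nc21`: 1970 mL/min/kg

Compound 3 holds the highest number of the three; the step of a 3.4-fold higher number from compound 1 to compound 3 (0.53 log units; beyond the scatter) and the step of a 3.4-fold higher number from compound 2 to compound 3 (0.53 log units; beyond the scatter) are both beyond the scatter, whereas no change at the digits printed from compound 1 to compound 2 (within the scatter) shows no change. Compound 4 `CN1CCN(c2ccc(Nc3ncc4c(=O)c(-c5c(Cl)cccc5Cl)cn(CC(C)(C)O)c4n3)cc2)CC1` differs from compound 3 by 1-hydroxy-1-methylethyl in place of (dimethylamino)methyl on a saturated chain carbon bound to an aromatic nitrogen. For the measured compounds named here, the only measured steps that bear on this site are those from compound 1 and compound 2 to compound 3, and both point the same way: the 2-(dimethylamino)ethyl group goes with the higher number. Going by the values given here, compound 4 moves away from that group, but the entering 1-hydroxy-1-methylethyl group is not represented among the measured compounds, so no step shows its own effect. On this basis a modest fall back toward the level of compound 1 and compound 2 is expected, with wide uncertainty. For compound 4 the estimate in this assay is 900 mL/min/kg, between 350 mL/min/kg and 2400 mL/min/kg, meaning an expected step of a 2.2-fold lower number from compound 3 to compound 4 (0.34 log units; beyond the scatter).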

Compound 4, clearance: 482 mL/min/kg
Estimate against measurement, compound 4: 1.9-fold (0.27 log units) above; measured number inside the range.
By their numbers in this assay, from the lowest: compounds 4, 1 and 2 (each within the scatter of the next); then compound 3.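

In this assay, 2-hydroxy-2-methylpropyl in place of 2-(dimethylamino)ethyl on an aromatic nitrogen gives a 4.1-fold lower number from compound 3 to compound 4 (0.61 log units; beyond the scatter), so an open saturated chain at this place does not by itself go with the higher number. The same group sits level with the two small rings, with a 1.2-fold lower number from compound 2 to compound 4 (0.08 log units; within the scatter) and a 1.2-fold lower number from compound 1 to compound 4 (0.08 log units; within the scatter), both within the scatter, which leaves compound 3 alone at the high end among these four compounds. No measurement at hand explains these numbers.

Still open, from the compounds shown here alone, is whether the high number follows the dimethylamino group specifically or any amine on this chain, which a primary amine, a morpholine-bearing ethyl chain or a carboxylic acid at the same place would test. Going by these compounds, all four compounds share the remaining structure, so whether these steps hold with another group in place of the methylpiperazine also remains open.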